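The compounds below may be only part of what the source reports. "The series", "measured", "known", "first", "only" and "open" are said of these compounds alone.

Measured compounds:
Compound 1 `Nc1nc(-c2ccc(Cl)cc2)c(CC(=O)O)s1`: > 100000 nM in an in vitro functional assay on HEK285-7 cells for antagonist activity at prostaglandin D2 receptor 2 (Homo sapiens), read by BRET and beta-arrestin recruitment; a higher number here means a weaker inhibitor, a lower number a stronger inhibitor (a limit of the assay, not a number).
Compound 2 `O=C(O)Cc1sc(C(c2ccccc2)c2ccccc2)nc1-c1ccc(F)cc1`: 77 nM in this assay.
Compound 3 `O=C(O)Cc1sc(C(c2ccc(F)cc2)c2ccc(F)cc2)nc1-c1cccc(F)c1`: 18 nM in this assay.

Of the two compounds that give a number in this assay, compound 3 stands lowest; compound 2 sits beyond the usual scatter above it. Compound 1 gives only a limit in this assay. Compound 4 `N#Cc1cc(-c2nc(C(c3ccc(F)cc3)c3ccc(F)cc3)sc2CC(=O)O)ccc1F` differs from compound 3 in one place: 3-cyano-4-fluorophenyl in place of 3-fluorophenyl on an aromatic carbon. Going by the values given here, no step of this kind is known among the measured compounds, so the size of the change cannot be read from them; a step from compound 3 to compound 4 of no more than the usual scatter, in either direction, is expected. On that basis compound 4 is estimated at 20 nM in this assay, within a range of 6 nM to 70 nM, which means an expected step of a 1.1-fold higher number from compound 3 to compound 4 (0.05 log units; within the scatter).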

Compound 4, half-maximal inhibitory concentration: 520 nM
Compound 4: the middle estimate sits 26-fold (1.41 log units) below what was measured, outside the stated range (above it).
By their numbers in this assay, from the lowest: compound 3; then compound 2; then compound 4. At a limit, above all of these: compound 1.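

This position on the shared core, next to the ring nitrogen, proves sensitive to what its phenyl ring carries: in this assay, 3-cyano-4-fluorophenyl in place of 3-fluorophenyl gives a 29-fold higher number from compound 3 to compound 4 (1.46 log units; beyond the scatter). A single change here is therefore enough to produce a large step, well beyond the scatter. The data shown offer no measured property that accounts for this step. From the compounds shown here alone, the nitrile and the added fluorine enter together, so which of them carries the step stays open. Also open, going by these compounds, is how a methoxy group or an amine on this phenyl ring would read.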